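This account rests on a few compounds, and the source may have more. Where it says the series, first, only, none or still open, it means among the compounds named here.

Measured compounds:
compound 1 `Cc1ccc([C@@H]2CN(C)[C@]3(C(=O)Nc4ccccc43)[C@]23Cc2ccccc2C3=O)cc1`: 27.4%
compound 2 `CN1C(=O)[C@@]2(c3ccccc31)N(C)C[C@@H](c1ccco1)[C@@]21Cc2ccccc2C1=O`: 17.5%
compound 3 `CN1C[C@@H](c2ccc(Cl)cc2)[C@@]2(Cc3ccccc3C2=O)[C@@]12C(=O)Nc1ccccc12`: 18.9%

In a functional assay on the whole organism (strain Wister albino) for inhibition, with Rattus norvegicus as the target, read by paw edema, with stated times of 1 h and 3 h, at a dose of 50 mg/kg by the intraperitoneal route (on this read-out lower numbers stand for less inhibition and higher numbers for more inhibition at the one dose given (going by the name of the read-out)), compound 3 gives 18.9%, the second highest of the three numbers. Within the data shown here, its nearest neighbour is compound 2 with 17.5%, within the scatter; the furthest is compound 1 with 27.4%, also within the scatter, and the one counted step, a number 8.5 percentage points lower from compound 1 to compound 3 (within the scatter), lies within the scatter as well.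

Compound 4 `CN1C[C@@H](c2ccco2)[C@@]2(Cc3ccccc3C2=O)[C@@]12C(=O)Nc1ccccc12` differs from compound 3 by furan-2-yl in place of 4-chlorophenyl on a saturated ring carbon. Among the measured compounds shown here, no measured step covers this exchange: the step from compound 1 to compound 3 concerns chloro in place of methyl on an aromatic carbon, a different change. Compound 2 carries furan-2-yl but differs from compound 3 in more than one place, so its value and that of compound 3 can only be set side by side, and the two lie within the scatter of each other. With all three measured numbers close together, the step of a number 0.9 percentage points lower from compound 3 to compound 4 (within the scatter) is expected to stay within the scatter. Compound 4 is therefore estimated at 18%, with a range from 10% to 27%.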

Compound 4, a percentage reported as inhibition, in the whole organism at one dose (the size of the read-out at that dose, not a potency): 38.8%
Beside the measured number, compound 4's estimate is 20.8 percentage points below it; measured number outside the range, above it.
By their numbers in this assay, from the lowest: compounds 2, 3 and 1 (each within the scatter of the next); then compound 4.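

In this assay, furan-2-yl in place of 4-chlorophenyl on the saturated ring carbon gives a number 19.9 percentage points higher from compound 3 to compound 4 (beyond the scatter), and furan-2-yl in place of 4-methylphenyl at the same carbon gives a number 11.4 percentage points higher from compound 1 to compound 4 (beyond the scatter), so this position now shows exchanges beyond the scatter, both in the same direction. Furan-2-yl alone does not give the higher number: with that group kept, hydrogen in place of methyl on the amide-type nitrogen gives a number 21.3 percentage points higher from compound 2 to compound 4 (beyond the scatter), so the amide hydrogen counts as well within this set. No measurement shown here speaks to the reason for these steps.

Open, on these data alone, is whether thiophen-2-yl or cyclohexyl at the saturated ring carbon keeps the higher number. Also open, as far as these compounds go, is how an ethyl group or a longer chain on the amide-type nitrogen compares with hydrogen and methyl.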